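Phenyl for cyclopropyl on a diamino pyrimidine series

A few compounds are considered here, and "the series" means these few. Any claim that something is new, unique, unknown or untested is made for them only; others in the source may bear on it.

Going by the values given here, compound 2 `C[C@H](Nc1nc(N)nc(N)c1C#N)c1c(C2CC2)c(=O)n2cc(F)ccc2c1-c1ccc(F)cc1` gives 35% in an ADME assay on microsomes from liver (Rattus norvegicus), read by LC-MS, using NADPH, with a stated time of 30 min, tested at 1 uM (on this read-out lower numbers stand for a less stable compound and higher numbers for a more stable compound), the higher of the two numbers so far; compound 1 `C[C@H](Nc1ncnc(N)c1C#N)c1c(C2CC2)c(=O)n2cc(F)ccc2c1-c1ccc(F)cc1` gives 1%, and the step of a number 34 percentage points higher from compound 1 to compound 2 (beyond the scatter) is the only measured change. Compound 3 `C[C@H](Nc1nc(N)nc(N)c1C#N)c1c(-c2ccccc2)c(=O)n2cc(F)ccc2c1-c1ccc(F)cc1` differs from compound 2 by phenyl in place of cyclopropyl on an aromatic carbon. Among the compounds with values here, no measured step touches this exchange, so nothing in the data sets its size or direction. The step of a number 10 percentage points lower from compound 2 to compound 3 (within the scatter) is therefore expected to be small against a wide range. Compound 3 is estimated at 25%, between 5% and 50%.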

Compound 3, percent of the compound remaining: 77%
Estimate against measurement, compound 3: 52 percentage points below; measured number above the stated range.
By their numbers in this assay, from the lowest: compound 1; then compound 2; then compound 3.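

In this assay, this aromatic carbon proves to be a second place where one change moves the read-out strongly: with the amino group kept, phenyl in place of cyclopropyl gives a number 42 percentage points higher from compound 2 to compound 3 (beyond the scatter). The larger, aromatic ring is thus compatible with a higher number here, at least on this core. No measurement shown accounts for the rise. On these data alone, it remains open whether a pyridyl ring or an isopropyl group on this carbon would read like phenyl or like cyclopropyl, and whether phenyl gives a similar step on the core of compound 1.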